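Oral exposure: fluoro on the anilide ring of compound 2

A few compounds are considered here, and "the series" means these few. Any claim that something is new, unique, unknown or untested is made for them only; others in the source may bear on it.

Measured so far:
compound 1 `CC(C)(C)S(=O)(=O)Nc1ccc(-c2c(C(N)=O)c3cc(F)c(OC(F)F)cc3n2C2CCCCC2)c(F)c1` gives 1720 ng.h/mL
compound 2 `CC(C)(C)S(=O)(=O)Nc1ccc(-c2c(C(N)=O)c3cc(F)c(OC(F)F)cc3n2-c2ccccc2)cc1` gives 7670 ng.h/mL

Going by the values given here, in an ADME assay on the whole organism (plasma, strain Sprague-Dawley) for pharmacokinetics, with Rattus norvegicus as the target, with stated times of 6 h and 30 min, at a dose of 10 mg/kg by the oral route (on this read-out lower numbers stand for lower exposure and higher numbers for higher exposure at the dose given), compound 2 stands highest of the two numbers; compound 1, the nearest, lies well beyond the scatter below it, though the two differ in more than one place, so no single step is drawn. Compound 3 `CC(C)(C)S(=O)(=O)Nc1ccc(-c2c(C(N)=O)c3cc(F)c(OC(F)F)cc3n2-c2ccccc2)c(F)c1` differs from compound 2 by fluoro in place of hydrogen on an aromatic carbon. Among the compounds with values here, with no single step to lean on, only a small change is expected, likely within the scatter and if anything downward. For compound 3 the estimate is 5500 ng.h/mL, between 2300 ng.h/mL and 12000 ng.h/mL, a step of a 1.4-fold lower number from compound 2 to compound 3 (0.14 log units; within the scatter).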

Compound 3, area under the concentration-time curve: 4360 ng.h/mL
Compound 3: the middle estimate sits 1.3-fold (0.10 log units) above what was measured; low and high end bracket the measured number.
By their numbers in this assay, from the lowest: compound 1; then compounds 3 and 2 (each within the scatter of the next).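

Fluoro in place of hydrogen on this aromatic carbon, ortho to a large group and meta to a ((tert-butyl)sulfonyl)amino group, gives a 1.8-fold lower number from compound 2 to compound 3 (0.25 log units; within the scatter) in this assay, so oral exposure in the rat holds up with this change. Going by these compounds alone, the same fluoro-bearing ring also allows the first one-place reading on the aromatic nitrogen: phenyl in place of cyclohexyl gives a 2.5-fold higher number from compound 1 to compound 3 (0.40 log units; beyond the scatter), a modest gain.

Going by these compounds, whether chloro, methoxy or an amine at this carbon would also hold exposure remains open. Nothing shown bears on what sets the size of either step.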